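The compounds below may be only part of what the source reports. "The series", "measured", "known", "first", "only" and "open" are said of these compounds alone.

Series notes on the amide chain length. Compound 1 `CCCCCCC(=O)NCC(C)(C)CC1=C(O)C(=O)c2ccccc2C1=O` gives 28200 nM in a functional assay on KB cells (Homo sapiens) for cytotoxicity, read by resazurin assay, with a stated time of 3 days; a higher number here means a weaker inhibitor, a lower number a stronger inhibitor. Compound 2 `CCCCCCCCC(=O)NCC(C)(C)CC1=C(O)C(=O)c2ccccc2C1=O` carries ethyl in place of hydrogen on a saturated chain carbon, six bonds along the chain from a carbonyl carbon and in this assay gives 19700 nM; the step is a 1.4-fold lower number from compound 1 to compound 2 (0.16 log units; within the scatter). Compound 3 `CCCCCCCCCCCCCC(=O)NCC(C)(C)CC1=C(O)C(=O)c2ccccc2C1=O` differs from compound 1 by heptyl in place of hydrogen on a saturated chain carbon, six bonds along the chain from a carbonyl carbon; in this assay compound 3 gives 25100 nM. Compound 4 `CCCCCCCCCCCCCCCC(=O)NCC(C)(C)CC1=C(O)C(=O)c2ccccc2C1=O` is not yet measured; it differs from compound 3 by ethyl in place of hydrogen on a saturated chain carbon, ten or more bonds along the chain from a carbonyl carbon. This is the same kind of change as that from compound 1 to compound 2, but the place along the chain is not identical, as the two differences show. With three chain lengths already within the scatter of one another, the expected step of a 1.1-fold lower number from compound 3 to compound 4 (0.04 log units; within the scatter) rests on the flat reading of a 1.4-fold lower number from compound 1 to compound 2 (0.16 log units; within the scatter). Compound 4 is therefore expected to give 23000 nM, between 10000 nM and 50000 nM.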

Compound 4, half-maximal inhibitory concentration: 5120 nM
Compound 4: the middle estimate sits 4.5-fold (0.65 log units) above what was measured; measured number below the stated range.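

In this assay, ethyl in place of hydrogen gives a 4.9-fold lower number from compound 3 to compound 4 (0.69 log units; beyond the scatter), which does not match the same change on the shorter chain: the same change on two cores in this assay, a 1.4-fold lower number (0.16 log units; within the scatter) from compound 1 to compound 2 and a 4.9-fold lower number (0.69 log units; beyond the scatter) from compound 3 to compound 4, 3.4-fold (0.53 log units) apart, beyond the scatter of two such steps. Heptyl in place of hydrogen gives a 3.8-fold lower number from compound 2 to compound 4 (0.59 log units; beyond the scatter), which also differs from its earlier counterpart: the same change on two cores in this assay, a 1.1-fold lower number (0.05 log units; within the scatter) from compound 1 to compound 3 and a 3.8-fold lower number (0.59 log units; beyond the scatter) from compound 2 to compound 4, 3.4-fold (0.53 log units) apart, beyond the scatter of two such steps. With nonyl in place of hydrogen giving a 5.5-fold lower number from compound 1 to compound 4 (0.74 log units; beyond the scatter), compound 4 stands apart from compounds 1, 2 and 3, so a chain extension does not carry a constant step from one core to another, though these four chains do not show how the step depends on length.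

The compounds shown leave open whether a longer chain would extend this step or reverse it in this assay. They also leave open how an amine or a carboxylic acid on the chain would read.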